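The compounds below may be only part of what the source reports. "The series", "measured", "known", "first", "only" and "open" are said of these compounds alone.

In a functional assay on SW480 cells (Homo sapiens) for antiproliferative activity, read by MTT assay, with a stated time of 48 h (on this read-out lower numbers stand for stronger inhibition and higher numbers for weaker inhibition), compound 1 `Nc1nc(N2CCCC2)sc1C(=O)/C=C/c1ccc(Cl)cc1` gives 19.9 ug/mL, and compound 2 `Nc1nc(N2CCCC2)sc1C(=O)/C=C/c1ccc(Br)cc1` gives 15.8 ug/mL. Among the measured compounds shown here, compound 2 is one of only two compounds measured, and a 1.3-fold lower number from compound 1 to compound 2 (0.10 log units; within the scatter) shows that its number and that of compound 1 lie within the scatter. Compound 3 `Nc1nc(N2CCCC2)sc1C(=O)/C=C/c1ccc([N+](=O)[O-])cc1` differs from compound 2 by nitro in place of bromo on an aromatic carbon. For the measured compounds named here, the single measured step exchanged one halogen for another and does not bear on a nitro group, so in this assay no step beyond the scatter is expected, as a 1.0-fold higher number from compound 2 to compound 3 (0.01 log units; within the scatter). Compound 3 is therefore estimated at 16 ug/mL, within 6 ug/mL to 40 ug/mL.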

Compound 3, half-maximal inhibitory concentration: 22.4 ug/mL
For compound 3 the middle estimate is 1.4-fold (0.15 log units) below the measured one; the measured number falls inside the stated range.
By their numbers in this assay, from the lowest: compounds 2, 1 and 3 (each within the scatter of the next).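

Among the compounds shown here, at this place on the aromatic ring, para to a large group, nitro is the first group that is not a halogen, and in this assay it still leaves the number within the scatter, with a 1.4-fold higher number from compound 2 to compound 3 (0.15 log units; within the scatter) and a 1.1-fold higher number from compound 1 to compound 3 (0.05 log units; within the scatter). The earlier pair had shown only one halogen exchanged for another, whereas these steps extend that flat reading to a different kind of group. No evidence is available to explain this result. The compounds shown leave open whether an amine or a carboxylic acid at this place would also stay within the scatter, and whether changes elsewhere on the shared core would move the number further.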